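Methoxy for Dimethylamino on Two Related Cores

The compounds below may be only part of what the source reports. "The series", "measured", "known", "first", "only" and "open" are said of these compounds alone.

Compound 1, `CN(C)c1cccc(Nc2nccc(-c3cccnc3)n2)c1`, gives 1800 nM in a functional assay for inhibition, with Homo sapiens as the target; a higher number here means a weaker inhibitor, a lower number a stronger inhibitor.
Compound 2, `COc1cccc(Nc2nccc(-c3cccnc3)n2)c1`, gives 300 nM in this assay.
Compound 3, `CN(C)c1ccc(Nc2nccc(-c3ccccn3)n2)cc1`, gives 3300 nM in this assay.

Compound 2 differs from compound 1 by methoxy in place of dimethylamino on an aromatic carbon, and this gave a 6.0-fold lower number from compound 1 to compound 2 (0.78 log units; beyond the scatter). Compound 4, `COc1ccc(Nc2nccc(-c3ccccn3)n2)cc1`, differs from compound 3 by methoxy in place of dimethylamino on an aromatic carbon. This is the same kind of change, though here the group sits para to a large group rather than meta to a large group. The difference between the core of compound 3 and the core of compound 1 is not broken down here. Because the earlier change gave a 6.0-fold lower number from compound 1 to compound 2 (0.78 log units; beyond the scatter), a step in the same direction is expected, a 4.7-fold lower number from compound 3 to compound 4 (0.67 log units; beyond the scatter) in this assay, kept smaller since the place and the core both differ. Compound 4 is estimated at 700 nM, expected to lie between 250 nM and 2200 nM.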

Compound 4, half-maximal inhibitory concentration: 8300 nM
For compound 4 the middle estimate is 12-fold (1.07 log units) below the measured one; the whole stated range lies below it.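

In this assay, methoxy in place of dimethylamino on an aromatic carbon gave a 2.5-fold higher number from compound 3 to compound 4 (0.40 log units; beyond the scatter), the opposite direction to the earlier step. The change therefore did not carry in a fixed direction from one core to the other: the same change on two cores in this assay, a 6.0-fold lower number (0.78 log units; beyond the scatter) from compound 1 to compound 2 and a 2.5-fold higher number (0.40 log units; beyond the scatter) from compound 3 to compound 4, 15-fold (1.18 log units) apart, beyond the scatter of two such steps The two pairs differ in both the core and the place of the group, and they do not show which of these two differences goes with the reversal.

The compounds shown leave open how the change behaves when the core stays fixed and only the place of the group differs. Also open, going by these compounds, is how a primary amine or a longer ether chain on that carbon would read in this assay.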